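The source may hold more compounds than are shown below. What is called first, only, known or untested is meant among the compounds shown, and "the series" means these compounds.

Compound 1 `O=C1/C(=C/c2ccccc2F)CN(S(=O)(=O)c2ccc(Br)cc2)C/C1=C\c1ccccc1F` and compound 2 `N#Cc1ccc(S(=O)(=O)N2C/C(=C\c3ccccc3F)C(=O)/C(=C/c3ccccc3F)C2)cc1` share one core, while compound 3 `O=C1/C(=C/c2cccc(F)c2)CN(S(=O)(=O)c2ccc(Br)cc2)C/C1=C\c1cccc(F)c1` and compound 4 `N#Cc1ccc(S(=O)(=O)N2C/C(=C\c3cccc(F)c3)C(=O)/C(=C/c3cccc(F)c3)C2)cc1` share another; the difference between the two cores is not broken down here. In a functional assay on HepG2 cells (Homo sapiens) for cytotoxicity, read by MTT assay, with a stated time of 24 h (on this read-out lower numbers stand for stronger inhibition and higher numbers for weaker inhibition), compound 1 gives 13700 nM, compound 2 gives 16500 nM, and compound 3 gives 7700 nM. Among the compounds with values here, the single change between compound 1 and compound 2 is cyano in place of bromo on an aromatic carbon, and it made a step of a 1.2-fold higher number from compound 1 to compound 2 (0.08 log units; within the scatter). From compound 3 to compound 4 the change is cyano in place of bromo on an aromatic carbon, the same change in the same surroundings. Because the earlier step of a 1.2-fold higher number from compound 1 to compound 2 (0.08 log units; within the scatter) stayed within the scatter, a similarly small step is expected here, a 1.2-fold higher number from compound 3 to compound 4 (0.08 log units; within the scatter). Compound 4 is therefore estimated at 9200 nM in this assay, with an expected range from 5000 nM to 17000 nM.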

Compound 4, half-maximal inhibitory concentration: 2600 nM
For compound 4 the middle estimate is 3.5-fold (0.55 log units) above the measured one, outside the stated range (below it).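

In this assay, putting cyano in place of bromo gave a 3.0-fold lower number from compound 3 to compound 4 (0.47 log units; beyond the scatter), and this step did not match the one seen on the other core: the same change on two cores in this assay, a 1.2-fold higher number (0.08 log units; within the scatter) from compound 1 to compound 2 and a 3.0-fold lower number (0.47 log units; beyond the scatter) from compound 3 to compound 4, 3.6-fold (0.55 log units) apart, beyond the scatter of two such steps In these two pairs, then, the size of the step changes with the core, so a step measured on one core is a poor guide to the same change on the other. This does not show which feature of the two cores causes the gap, and two pairs give no general rule for other cores.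

The compounds shown leave open how a carboxylic acid, an amine or a methoxy group would behave in place of bromo on either core. They also leave open what the same change would do on a third core.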